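Ether chain change on the shared core, compound 2 to 3

A few compounds are considered here, and "the series" means these few. Any claim that something is new, unique, unknown or untested is made for them only; others in the source may bear on it.

Compound 1 `CC(C(=O)NCc1ccc(C(C)(C)C)nc1N1CCCCCC1)c1ccc(NS(C)(=O)=O)c(F)c1` gives 0.9 nM in an assay on cells for antagonist activity at transient receptor potential cation channel subfamily V member 1 (Homo sapiens), read by FLIPR and calcium flux, with a stated time of 6 min; on this read-out higher numbers stand for weaker inhibition and lower numbers for stronger inhibition. Compound 2 `CCCCCCOc1nc(C(C)(C)C)ccc1CNC(=O)C(C)c1ccc(NS(C)(=O)=O)c(F)c1` gives 2.7 nM and stands highest of the two numbers, the step of a 3.0-fold higher number from compound 1 to compound 2 (0.48 log units; beyond the scatter) lying beyond the scatter. Compound 3 `CC(C(=O)NCc1ccc(C(C)(C)C)nc1OC1CCCC1)c1ccc(NS(C)(=O)=O)c(F)c1` differs from compound 2 by cyclopentyl in place of hexyl on an oxygen on an aromatic ring. Going by the values given here, no measured step bears directly on this change: the only recorded step, a 3.0-fold higher number from compound 1 to compound 2 (0.48 log units; beyond the scatter), swaps the group on an aromatic carbon rather than the chain on the oxygen, so it offers no direction. For compound 3 the expected step of a 1.1-fold higher number from compound 2 to compound 3 (0.05 log units; within the scatter) is therefore none beyond the scatter. Compound 3 is estimated at 3 nM, within a range of 1.2 nM to 8 nM.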

Compound 3, inhibition constant: 1.5 nM
Estimate against measurement, compound 3: 2.0-fold (0.30 log units) above, within the range that was stated.
By their numbers in this assay, from the lowest: compounds 1, 3 and 2 (each within the scatter of the next, the first and the last beyond it).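

In this assay cyclopentyl in place of hexyl on the oxygen gives a 1.8-fold lower number from compound 2 to compound 3 (0.26 log units; within the scatter) and so shows that this oxygen carries a ring as well as an open chain with no difference beyond the scatter. Cyclopentyloxy in place of azepan-1-yl gives a 1.7-fold higher number from compound 1 to compound 3 (0.22 log units; within the scatter) and so, unlike hexyloxy in compound 2, does not separate from the azepan-1-yl group of compound 1. No evidence is available that explains these results.

Open, going by these compounds, is whether a shorter chain such as methyl on the oxygen stays in the same range. Also open, on these data alone, is how a cyclopentyl ring carrying a hydroxyl or an amine reads here.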